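Changing the Aryl Group on the Ring Amine Nitrogen

The source may report more compounds than this note shows. Statements on the series, on what has been measured and on what is new or still open speak of the compounds shown alone.

compound 1 `CCCc1nc(-c2ccccc2)c(CNCCN2CCN(C(c3ccccc3)c3ccccc3)CC2)o1` — 7470 nM
compound 2 `CCCc1nc(-c2ccccc2)c(CNCCCN2CCN(c3ccccc3F)CC2)o1` — 16100 nM

Of the compounds shown here, two have been measured in an assay on HEK293 cells for inhibition of Voltage-dependent T-type calcium channel subunit alpha-1G (Homo sapiens), read by patch clamp; a higher number here means a weaker inhibitor, a lower number a stronger inhibitor. Compound 1 gives 7470 nM in this assay. Compound 2 gives 16100 nM in this assay, the higher of the two numbers; the gap between compound 2 and compound 1 lies beyond the usual scatter, so compound 2 is the weaker inhibitor of the pair. Among the compounds with values here, the two compounds differ in more than one place, so no single step between them is drawn.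

Compound 3 `CCCc1nc(-c2ccccc2)c(CNCCCN2CCN(c3cccc(C)c3C)CC2)o1` is not yet measured. It differs from compound 2 in one place: 2,3-dimethylphenyl in place of 2-fluorophenyl on an amine nitrogen in a ring. Within the data shown here, no measured pair shows what this kind of exchange does in this assay, so there is no anchor for the size of the step. Compound 3 is therefore expected to stay close to compound 2, with a step from compound 2 to compound 3 of a 1.2-fold lower number from compound 2 to compound 3 (0.09 log units; within the scatter) expected, which is no more than the scatter would allow. The estimate for compound 3 in this assay is 13000 nM, with a range from 4000 nM to 40000 nM.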

Compound 3, half-maximal inhibitory concentration: 1780 nM
Compound 3: the middle estimate sits 7.3-fold (0.86 log units) above what was measured; the measured number lies below the stated range.
By their numbers in this assay, from the lowest: compound 3; then compound 1; then compound 2.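

With the rest of the molecule unchanged, the exchange of 2-fluorophenyl for 2,3-dimethylphenyl on the amine nitrogen in the ring gives a 9.0-fold lower number from compound 2 to compound 3 (0.96 log units; beyond the scatter) in this assay. Within the data shown here, this is the first step that isolates a single place, and it shows that the aryl group at this nitrogen can move the number beyond the scatter, here towards stronger inhibition. The compounds give no information on which feature of the exchange accounts for the size of this step.

On these data alone, because the step replaces one substituted phenyl with another, it remains open whether the change comes from losing the fluorine, from one of the methyl groups alone, or from the two methyl groups together; a plain phenyl, a 2-methylphenyl or a 3-methylphenyl group on the same nitrogen would separate these readings. It is also open whether 2,3-dimethylphenyl has a comparable effect when the chain linking the two ring systems is shorter, as the single pair shown here speaks only for the chain shared by compound 2 and compound 3.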